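Carboxymethyl removal from an inactive pair

The source may report more compounds than this note shows. Statements on the series, on what has been measured and on what is new or still open speak of the compounds shown alone.

Compound 1 `COc1ccc(-c2oc3c(CC=C(C)C)c(OC(C)C(=O)O)cc(O)c3c(=O)c2O)cc1` gives > 100000 nM as a limit
Compound 2 `COc1ccc(-c2oc3c(CC=C(C)C)c(OCC(=O)O)cc(O)c3c(=O)c2OCC(=O)O)cc1` gives > 100000 nM as a limit

Both readings come from a functional assay on MCF7 cells (Homo sapiens) for cytotoxicity, read by MTT assay (on this read-out higher numbers stand for weaker inhibition and lower numbers for stronger inhibition), and neither is a number. Compound 2 stands at the limit of > 100000 nM in this assay, at which 2 of the 2 values shown sit, and so offers no exact value to start from. Compound 3 `COc1ccc(-c2oc3c(CC=C(C)C)c(OCC(=O)O)cc(O)c3c(=O)c2O)cc1` has not yet been measured. It differs from compound 2 by hydrogen in place of carboxymethyl on an oxygen on an aromatic ring, the same difference reading as carboxymethoxy to hydroxy. Among the compounds with values here, no step between measured compounds is available as a guide. The expectation therefore leans on compound 1, whose reading of > 100000 nM is likewise a limit. No change beyond the scatter is expected in this assay in either direction. The estimated step of a number no higher from compound 2 to compound 3 (the limit leaves the size open) is expected to stay within that scatter. Compound 3 is estimated at 100000 nM with an expected range from 50000 nM to 200000 nM and will most likely be reported as a limit again.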

Compound 3, half-maximal inhibitory concentration: > 100000 nM
Compound 3 was reported as a limit; the forecaster's own chance of this, stated with the estimate: 85%; the middle value sits exactly at the limit.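

In this assay compound 3 gives > 100000 nM as a limit and not a number. The steps linking compound 3 with compound 1 and with compound 2 cannot be read: the limit of > 100000 nM in this assay, at which 3 of the 3 values shown sit. The compounds shown leave open how far each of the three lies from that limit, and whether any change on the shared core gives an exact value.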